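The compounds below may be only part of what the source reports. "The series", "measured", "known", "first", "only" and "open" are said of these compounds alone.

Compound 1 `CCOC(=O)C1=C(C)NC(=S)NC1c1cn(C(=O)CNc2ccc([N+](=O)[O-])c(Cl)c2)c2ccccc12` carries a chlorine on the ring that bears the nitro group and a thione on the shared core. For the measured compounds named here, in a physicochemical assay for lipophilicity (a higher number here means a more lipophilic compound, a lower number a more polar compound), compound 1 gives 3.4, the highest of the two numbers measured so far. Compound 2 `CCOC(=O)C1=C(C)NC(=O)NC1c1cn(C(=O)CNc2ccc([N+](=O)[O-])cc2)c2ccccc12` differs from compound 1 in two places, not one, and in this assay compound 2 gives 1.48, a value far enough below that of compound 1 to lie beyond the usual scatter. The two measured compounds differ in more than one place. No single change can be read from their gap.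

Compound 3 `CCOC(=O)C1=C(C)NC(=S)NC1c1cn(C(=O)CNc2ccc([N+](=O)[O-])cc2)c2ccccc12` differs from compound 1 in one place only: hydrogen in place of chloro on an aromatic carbon. Going by the values given here, no measured pair shows this change on its own. The expectation for this assay is a step of moderate size downward, beyond the scatter but much smaller than the gap between compound 1 and compound 2, and the step from compound 1 to compound 3 is estimated at a number 0.60 log units lower from compound 1 to compound 3 (beyond the scatter). In this assay compound 3 is therefore expected to give about 2.8, within a range from 2.3 to 3.3.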

Compound 3, partition coefficient: 2.88
Beside the measured number, compound 3's estimate is 0.08 log units below it, and the stated range covers the measured number.
By their numbers in this assay, from the lowest: compound 2; then compound 3; then compound 1.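

In this assay, hydrogen in place of chloro on an aromatic carbon, ortho to a nitro group, can now be read as a change of its own: the loss of this one heavy atom gives a number 0.52 log units lower from compound 1 to compound 3 (beyond the scatter), a modest step. Compound 3 also connects the remaining pair, as it differs from compound 2 in one place only, the thione on the shared core where compound 2 has a carbonyl; in this pair, compound 3 gives 2.88 and compound 2 gives 1.48. The measurements record the size of the chloro step, but nothing available explains why the number moves as it does at this position.

This single pair cannot show whether the same swap would give a step of similar size elsewhere on the ring or on a core carrying the carbonyl. The compounds shown also leave open what a fluorine atom, a methoxy group or an amine would give on this same aromatic carbon, ortho to the nitro group.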